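Working notes on cytotoxicity across the amide cap

The source may report more compounds than this note shows. Statements on the series, on what has been measured and on what is new or still open speak of the compounds shown alone.

Compound 1, `CCc1ccc(C(=O)NCCCN2CCN(CCCNc3ccnc4cc(Cl)ccc34)CC2)cc1`, in an ADME assay on L6 cells (Rattus norvegicus) for cytotoxicity (on this read-out lower numbers stand for stronger inhibition and higher numbers for weaker inhibition), gives 3900 nM.
Compound 2, `O=C(CCCCc1ccccc1)NCCCN1CCN(CCCNc2ccnc3cc(Cl)ccc23)CC1`, in this assay gives 9400 nM.

Compound 1 holds the lowest of the two numbers in this assay; its nearest neighbour is compound 2, a 2.4-fold higher number from compound 1 to compound 2 (0.38 log units; beyond the scatter). Compound 3, `O=C(NCCCN1CCN(CCCNc2ccnc3cc(Cl)ccc23)CC1)c1cc(Cl)cc(Cl)c1`, differs from compound 1 as follows: 3,5-dichlorophenyl in place of 4-ethylphenyl on a carbonyl carbon. Within the data shown here, the single measured step touches the same carbonyl carbon but is a different exchange, so no measured pair isolates this change. The expectation for compound 3 is therefore no step beyond the scatter, a 1.1-fold lower number from compound 1 to compound 3 (0.05 log units; within the scatter). Compound 3 is estimated at 3500 nM, within a range from 1500 nM to 9000 nM.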

Compound 3, half-maximal inhibitory concentration: 3000 nM
The estimate for compound 3 lay 1.2-fold (0.07 log units) above the measured number, within the range that was stated.
By their numbers in this assay, from the lowest: compounds 3 and 1 (each within the scatter of the next); then compound 2.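

In this assay, 3,5-dichlorophenyl in place of 4-ethylphenyl on the carbonyl carbon gives a 1.3-fold lower number from compound 1 to compound 3 (0.11 log units; within the scatter), so these two groups cannot be told apart at this position. Against 4-phenylbutyl, the 3,5-dichlorophenyl group gives a 3.1-fold lower number from compound 2 to compound 3 (0.50 log units; beyond the scatter), leaving compound 2 with the highest number of the three. Nothing available accounts for these numbers.

The compounds shown leave open whether a single chlorine on the phenyl ring would read like the two in compound 3. On these data alone, how a carboxylic acid or an amine on the cap would read also remains open.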